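The source may hold more compounds than are shown below. What is called first, only, known or untested is meant among the compounds shown, and "the series" means these compounds.

Working notes on the series. Compound 2 `Cn1c(-c2ccccc2C(F)(F)F)nnc1C12CCC(CNS(C)(=O)=O)(CC1)CC2` is measured in an assay on CHO-K1 cells for inhibition of 11-beta-hydroxysteroid dehydrogenase type 2 (Mus musculus), read by scintillation proximity assay; on this read-out lower numbers stand for stronger inhibition and higher numbers for weaker inhibition. In this assay compound 2 gives > 4000 nM, which is a limit of the assay and not a number. Compound 1 `CCSCCC12CCC(c3nnc(-c4ccccc4C(F)(F)F)n3C)(CC1)CC2` gives in this assay > 4000 nM, again a limit. Compound 3 `CCS(=O)(=O)CCC12CCC(c3nnc(-c4ccccc4Br)n3C)(CC1)CC2` gives in this assay > 4000 nM, also a limit. Compound 2 thus stands on no number of its own, and the two further values shown are limits as well; all three sit at the limit of > 4000 nM in this assay, at which 3 of the 3 values shown sit. Within the data shown here, the one step between measured compounds, a step that the two limits leave unreadable from compound 1 to compound 2, is unreadable for that reason. Compound 4 `CC(C)S(=O)(=O)CCC12CCC(c3nnc(-c4ccccc4C(F)(F)F)n3C)(CC1)CC2` differs from compound 2 by (isopropylsulfonyl)methyl in place of methanesulfonamido on a saturated chain carbon bound to a saturated ring carbon. Among the measured compounds shown here, no measured step bears on this change in a readable size; the values of compounds 1, 2 and 3 show nothing but the same limit. The expected step in this assay is estimated as a step that the limit leaves unreadable from compound 2 to compound 4, none beyond the scatter. Compound 4 is expected to give about 6000 nM in this assay, within 2000 nM to 30000 nM, most probably again as a limit only.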

Compound 4, half-maximal inhibitory concentration: > 4000 nM
Compound 4 ended at the assay's limit; the forecaster's own chance of this, stated with the estimate: 80%; the middle value lies beyond the limit too.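

The steps from compound 1 and from compound 2 to compound 4 cannot be read, all these values being limits of the assay and not numbers: the limit of > 4000 nM in this assay, at which 4 of the 4 values shown sit. Left open is what number any compound shown would give in this assay, and how large any of these changes is there.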